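Trichlorophenyl for Acetamidophenyl in a Series Sitting at the Limit

A few compounds are considered here, and "the series" means these few. Any claim that something is new, unique, unknown or untested is made for them only; others in the source may bear on it.

Compound 1 `COc1ccc(-n2nncc2CN2C(=O)C3(C(C#N)=C(N)Oc4c3c3nc5ccccc5nc3c3ccccc43)c3ccccc32)cc1`: in a functional assay on HepG2 cells (Homo sapiens) for antiproliferative activity, read by MTT assay, with a stated time of 48 h (on this read-out higher numbers stand for weaker inhibition and lower numbers for stronger inhibition), compound 1 gives > 50000 nM, a limit of the assay.
Compound 2 `COc1ccccc1-n1nncc1CN1C(=O)C2(C(C#N)=C(N)Oc3c2c2nc4ccccc4nc2c2ccccc32)c2ccccc21`: in this assay compound 2 gives > 50000 nM, a limit of the assay.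
Compound 3 `CC(=O)Nc1ccc(-n2nncc2CN2C(=O)C3(C(C#N)=C(N)Oc4c(N)cc5nc6ccccc6nc5c43)c3ccccc32)cc1`: in this assay compound 3 gives > 50000 nM, a limit of the assay.

Compound 3 stands where every measured member of this set stands, at the limit of > 50000 nM in this assay, at which 3 of the 3 values shown sit, so no number for it is known, only that it lies beyond what this assay can read. Within the data shown here, the single step between measured compounds, a step that the two limits leave unreadable from compound 1 to compound 2, joins two limits and therefore carries no size; it says nothing about how a change on the aromatic nitrogen shifts the read-out.

Compound 4 `N#CC1=C(N)Oc2c(N)cc3nc4ccccc4nc3c2C12C(=O)N(Cc1cnnn1-c1c(Cl)cc(Cl)cc1Cl)c1ccccc12` differs from compound 3 in one place: 2,4,6-trichlorophenyl in place of 4-acetamidophenyl on an aromatic nitrogen.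

Among the measured compounds shown here, no measured step bears readably on this change, and the three limits give no direction. The expectation for compound 4 is accordingly that it remains at or beyond the limit as well, with the step that the limit leaves unreadable from compound 3 to compound 4 expected to be unreadable rather than a true gain. Compound 4 is therefore estimated at 60000 nM in this assay, within a range from 20000 nM to 200000 nM, with the most likely outcome being that only a limit is reported.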

Compound 4, half-maximal inhibitory concentration: 37800 nM
For compound 4 the middle estimate is 1.6-fold (0.20 log units) above the measured one; the measured number falls inside the stated range.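

Moving from 4-acetamidophenyl to 2,4,6-trichlorophenyl on the aromatic nitrogen brings this series into the readable range of this assay: compound 4 gives 37800 nM. From the compounds shown here alone, the change amounts to an at least 1.3-fold lower number from compound 3 to compound 4 (0.12 log units; that floor lies within the scatter), and this figure is a floor rather than a measured size, so how far the two compounds truly lie apart remains unknown. The earlier compounds shown here could not show that any group at this position yields a number at all, and compound 4 now stands alone inside the readable range while the others stay at the limit: the limit of > 50000 nM in this assay, at which 3 of the 4 values shown sit.

The compounds shown leave open whether the readable value follows from the three chlorine atoms or simply from the loss of the acetamido group, a question that a plain phenyl or a 4-chlorophenyl on the same nitrogen would help to separate. Going by these compounds, it also remains open whether 2,4,6-trichlorophenyl would give a readable value on the core of compound 1, which lacks the amine carried by the core of compound 3 and compound 4.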